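This account rests on a few compounds, and the source may have more. Where it says the series, first, only, none or still open, it means among the compounds named here.

Measured compounds in a functional assay on the whole organism (CCRF S-180 cells, Mus musculus) for inhibition, in a xenograft, with stated times of 7 days and 24 h, at a dose of 100 umol/kg by the intraperitoneal route; a lower number here means less inhibition, a higher number more inhibition at the dose given (going by the name of the read-out):
compound 1, `NC(=O)CC[C@H](NC(=O)c1cc2ccccc2cn1)C(=O)OCc1ccccc1`, 11.9%
compound 2, `O=C(CNC(=O)c1cc2ccccc2cn1)OCc1ccccc1`, 16.1%
compound 3, `C[C@H](NC(=O)c1cc2ccccc2cn1)C(=O)OCc1ccccc1`, 40.6%

Compound 3 has the highest of the three numbers; its nearest neighbour is compound 2, its furthest compound 1, and both gaps lie beyond the scatter. The step of a number 24.5 percentage points higher from compound 2 to compound 3 (beyond the scatter) and the step of a number 28.7 percentage points higher from compound 1 to compound 3 (beyond the scatter) both point the same way: the bare methyl chain on compound 3 stands above the shorter chain of compound 2 and above the longer carbamoylmethyl-bearing chain of compound 1. The step of a number 4.2 percentage points higher from compound 1 to compound 2 (within the scatter) is within the scatter.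

Compound 4, `O=C(N[C@@H](CO)C(=O)OCc1ccccc1)c1cc2ccccc2cn1`, is not yet measured. The change from compound 3 is hydroxy in place of hydrogen on a saturated chain carbon, two bonds along the chain from an amide-type nitrogen and a carbonyl carbon. Among the compounds with values here, no measured pair tests exactly this change. Within the data shown here, the one step touching the same chain carbon, a number 28.7 percentage points higher from compound 1 to compound 3 (beyond the scatter), shows that a group carrying an amide there goes with a lower number, and compound 2, with nothing on that carbon, also sits lower than compound 3. A drop is therefore expected for compound 4, modest in size and uncertain in extent; the step of a number 14.6 percentage points lower from compound 3 to compound 4 (beyond the scatter) is the estimate. In this assay compound 4 is expected to give 26%, within a range from 8% to 44%.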

Compound 4, a percentage reported as inhibition, in the whole organism at one dose (the size of the read-out at that dose, not a potency): 40.4%
The estimate for compound 4 lay 14.4 percentage points below the measured number; measured number inside the range.
By their numbers in this assay, from the lowest: compounds 1 and 2 (each within the scatter of the next); then compounds 4 and 3 (each within the scatter of the next).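

In this assay, hydroxy in place of hydrogen on this saturated chain carbon, which is methyl to hydroxymethyl when cut one bond further out, gives (a number 0.2 percentage points lower from compound 3 to compound 4 (within the scatter)), so the two groups cannot be told apart here. Hydroxymethyl also stands clear of the two other chains, with (a number 24.3 percentage points higher from compound 2 to compound 4 (beyond the scatter)) and (a number 28.5 percentage points higher from compound 1 to compound 4 (beyond the scatter)), so the higher number at this position is not tied to methyl alone, and an added heteroatom on this chain does not by itself go with a lower number. No supporting data bear on the reason for this result.

On these data alone, it remains open whether the same holds for other groups at this position, such as an amine, a carboxylic acid or a longer chain ending in hydroxy. As far as these compounds go, with every number in this assay taken at one dose, it also remains open whether compound 3 and compound 4 would stay within the scatter of each other at other doses.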